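Swapping phenoxy for chloro on the benzylic ring

The compounds below may be only part of what the source reports. "The series", "measured", "known", "first", "only" and "open" are said of these compounds alone.

The compounds share a core in which a pyridinone-type acid is joined through an ester to a benzyl alcohol. Compound 1 `COc1ccc(COC(=O)c2cccc(S)n2)cc1` carries a thiol on the ring and a methoxy on the benzyl part; in an assay on isolated protein for inhibition of matrix metalloproteinase-9 (Homo sapiens) (on this read-out higher numbers stand for weaker inhibition and lower numbers for stronger inhibition), compound 1 gives 95000 nM. Compound 2 `O=C(OCc1ccccc1)c1cccc(=O)[nH]1` is the plain benzyl ester, and in this assay compound 2 gives 69000 nM. Compound 3 `O=C(OCc1cccc(Oc2ccccc2)c1)c1cccc(=O)[nH]1` adds a phenoxy group to the benzyl ring. For compound 3 the result in this assay is only a limit, > 150 nM, so its place among the numbers is not fixed. The step that the limit leaves unreadable from compound 2 to compound 3 therefore cannot be sized, because of the limit of > 150 nM in this assay, at which 1 of the 3 values shown sits.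

Compound 4 `O=C(OCc1cccc(Cl)c1)c1cccc(=O)[nH]1` differs from compound 3 by chloro in place of phenoxy on an aromatic carbon. For the measured compounds named here, no measured step shows what a chloro contributes, and the one step touching this position is unreadable, so the expectation leans on compound 2 with 69000 nM. The expected step that the limit leaves unreadable from compound 3 to compound 4 cannot be judged against the scatter. Compound 4 is estimated at 50000 nM, between 8000 nM and 200000 nM.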

Compound 4, half-maximal inhibitory concentration: 67000 nM
Compound 4: the middle estimate sits 1.3-fold (0.13 log units) below what was measured; measured number inside the range.
By their numbers in this assay, from the lowest: compounds 4, 2 and 1 (each within the scatter of the next).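

Chloro on the benzyl ring gives the first readable step at this position: in this assay there is a 1.0-fold lower number from compound 2 to compound 4 (0.01 log units; within the scatter). Chloro in place of hydrogen on this aromatic carbon therefore leaves the number within the usual scatter, something the earlier compounds could not show. The steps that touch compound 3 cannot be read, since its result is only a limit: the limit of > 150 nM in this assay, at which 1 of the 4 values shown sits.

As far as these compounds go, whether phenoxy and chloro truly differ on this carbon stays open, as does whether phenoxy in compound 3 changes the number at all. From the compounds shown here alone, how an amine, a carboxylic acid or a longer chain on this same aromatic carbon would read in this assay also remains open.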